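Replacing a non-aromatic ring by an aromatic one on the shared core

A few compounds are considered here, and "the series" means these few. Any claim that something is new, unique, unknown or untested is made for them only; others in the source may bear on it.

Compound 1 `CCOc1cc(C(=O)Nc2ccc(Cl)c(C3=NCCN3)c2)cc(OCC)c1OCC` is a reference point without a number: in a functional assay on Shh Light II cells for inhibition of Sonic hedgehog protein (Mus musculus), read by reporter gene assay, with a stated time of 48 h, in the presence of a further agent that is not named here (on this read-out lower numbers stand for stronger inhibition and higher numbers for weaker inhibition), compound 1 is reported as "not active" (no number reported). Two measured relatives carry a different ring at the same place. Compound 2 `COc1cc(C(=O)Nc2ccc(Cl)c(-c3nc4ccccc4[nH]3)c2)cc(OC)c1OC` gives 79.8 nM in this assay, and compound 3 `O=C(Nc1ccc(Cl)c(-c2nc3ccccc3[nH]2)c1)c1ccc(Cl)cc1` gives 224 nM. Compound 4 `CCOc1cc(C(=O)Nc2ccc(Cl)c(-c3ncc[nH]3)c2)cc(OCC)c1OCC` differs from compound 1 in one spot (a group of 5 heavy atoms (3 carbon, 2 nitrogen; one five-membered aromatic ring with 2 hetero atoms) in place of a group of 5 heavy atoms (3 carbon, 2 nitrogen; one five-membered non-aromatic ring with 2 hetero atoms), on an aromatic carbon), so that an aromatic five-membered ring now stands where a non-aromatic one stood. He expects a step toward stronger inhibition in this assay, clearly beyond the scatter, because compound 2 gives 79.8 nM and compound 3 gives 224 nM with aromatic rings at that position. For compound 4 he therefore estimates 600 nM, within 100 nM to 5000 nM.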

Compound 4, half-maximal inhibitory concentration: "not active" (no number reported)
For compound 4 the study gives words and no number, and the estimate cannot be compared.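

Compound 1 and compound 4 are both reported in words only, so no step can be read between them. The compounds shown leave open which feature goes with measurable inhibition, and nothing shown offers an explanation.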